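The compounds below may be only part of what the source reports. "The series", "measured", "known", "first", "only" and "open" are said of these compounds alone.

The measured compounds:
- compound 1, `CCNC(=O)CCCSC[C@H](NC(=O)OCc1ccccc1)C(=O)Nc1ccccc1`: 15%
- compound 2, `O=C(CCCSC[C@H](NC(=O)OCc1ccccc1)C(=O)Nc1ccccc1)NCc1ccccc1`: 30%

Both were tested in an assay for inhibition of NAD-dependent protein deacylase sirtuin-6 (Homo sapiens), read by HPLC, with stated times of 15 min and 1 h, tested at 333 uM; on this read-out higher numbers stand for more inhibition at the one concentration tested (going by the name of the read-out) and lower numbers for less inhibition. Among the compounds with values here, compound 2 stands highest of the two numbers; its nearest neighbour is compound 1, and the only measured step runs between them, a number 15 percentage points higher from compound 1 to compound 2 (beyond the scatter), where a phenyl replaced a methyl on a saturated chain carbon bound to an amide-type nitrogen. The next compound, compound 3, `CCCCCCCCCCNC(=O)CCCSC[C@H](NC(=O)OCc1ccccc1)C(=O)Nc1ccccc1`, is reached from compound 2 by a change at that same place: nonyl in place of phenyl on a saturated chain carbon bound to an amide-type nitrogen.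

Within the data shown here, only the step from compound 1 to compound 2 bears on this, and it shows that a larger group at this position went with a modest rise in inhibition in this assay. Nonyl is larger again, but it is a chain and not a ring, and no measured compound carries a chain of this kind here, so the direction is uncertain. For compound 3 the expected step is a number 5 percentage points higher from compound 2 to compound 3 (within the scatter), which would not be beyond the scatter. Compound 3 is therefore estimated at 35%, with a range from 10% to 60%.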

Compound 3, a percentage reported as inhibition, at one concentration (the size of the read-out at that concentration, not a potency): 28%
Beside the measured number, compound 3's estimate is 7 percentage points above it, within the range that was stated.
By their numbers in this assay, from the lowest: compound 1; then compounds 3 and 2 (each within the scatter of the next).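

In this assay, putting nonyl in place of phenyl on a saturated chain carbon bound to an amide-type nitrogen gives a number 2 percentage points lower from compound 2 to compound 3 (within the scatter), so this assay does not tell the ring and the long chain apart at this position. Measured against the small ethyl group of compound 1, the octyl extension gives a number 13 percentage points higher from compound 1 to compound 3 (beyond the scatter), which shows that an aromatic ring is not needed for a modest rise: among these compounds, a chain with no ring also sits above compound 1, as phenyl does in compound 2. Nothing available explains why these groups go with these numbers, or why the ring and the chain give readings within scatter of each other.

Going by these compounds, it remains open whether a butyl chain, a cyclohexyl ring or an amine at this position would read like compound 2 and compound 3 or like compound 1, and so at what point along the chain the rise appears. On these data alone, each number also describes inhibition at a single concentration, so how compound 2 and compound 3 compare in potency remains unknown.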